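This account rests on a few compounds, and the source may have more. Where it says the series, first, only, none or still open, it means among the compounds named here.

Measured so far in an ADME assay on L02 cells (Homo sapiens) for antiproliferative activity, read by MTT assay, with a stated time of 48 h; a lower number here means a stronger inhibitor, a higher number a weaker inhibitor:

Compound 1 `CCc1ccccc1-n1nncc1CN1C(=O)C2(C(C#N)=C(N)Oc3c(N)cc4nc5ccccc5nc4c32)c2ccccc21`: compound 1 gives 22900 nM.
Compound 2 `COc1ccccc1-n1nncc1CN1C(=O)C2(C(C#N)=C(N)Oc3c(N)cc4nc5ccccc5nc4c32)c2ccccc21`: for compound 2 the assay reports only a limit, > 50000 nM.
Compound 3 `N#CC1=C(N)Oc2c(N)cc3nc4ccccc4nc3c2C12C(=O)N(Cc1cnnn1-c1c(F)cccc1F)c1ccccc12`: for compound 3 the assay likewise reports only a limit, > 50000 nM.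

Compound 3 therefore stands at the upper edge of what this assay reads; no number is known for it, and it shares that position with one other member of the set (the limit of > 50000 nM in this assay, at which 2 of the 3 values shown sit). Within the data shown here, compound 1 is the only compound with a readable number, and it is a weak inhibitor.

Compound 4 `Cc1ccc(-n2nncc2CN2C(=O)C3(C(C#N)=C(N)Oc4c(N)cc5nc6ccccc6nc5c43)c3ccccc32)cc1Cl` differs from compound 3 in one place: 3-chloro-4-methylphenyl in place of 2,6-difluorophenyl on an aromatic nitrogen. The measured steps that bear on this are those at the same aryl group on the triazole nitrogen and on its substituents. an at least 2.1-fold higher number from compound 1 to compound 2 (0.33 log units; beyond the scatter) and an at least 2.1-fold higher number from compound 1 to compound 3 (0.33 log units; beyond the scatter) both point toward weaker inhibition, each at least modest. a step that the two limits leave unreadable from compound 2 to compound 3 cannot be read, as both ends sit at the limit.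

Among the measured compounds shown here, no measured step shows a change at this aryl group that lowers the number, so for compound 4 no move below the limit is expected; the expected result in this assay is 50000 nM, with a range from 18000 nM to 120000 nM, corresponding to an expected step of a number no higher from compound 3 to compound 4 (the limit leaves the size open), and most probably the assay will again report only a limit.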

Compound 4, half-maximal inhibitory concentration: > 50000 nM
Compound 4: no number, only a limit (the forecaster's own chance of this, stated with the estimate: 65%); the middle value lies on the limit itself.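

Working from this assay, the 3-chloro-4-methylphenyl group on the aromatic nitrogen gives a third replacement for the 2-ethylphenyl group of compound 1, and it again moves the result upward (an at least 2.1-fold higher number from compound 1 to compound 4 (0.33 log units; beyond the scatter)). The earlier replacements, 2-methoxyphenyl and 2,6-difluorophenyl, carried oxygen or fluorine, so this result extends the finding to an aryl group bearing chlorine and methyl: among the four aryl groups shown, only the 2-ethylphenyl group of compound 1 gives a readable number, while the other three compounds reach the same limit (the limit of > 50000 nM in this assay, at which 3 of the 4 values shown sit). The steps among compound 2, compound 3 and compound 4 cannot be read, so these three aryl groups cannot be ranked against one another.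

Still open, as far as these compounds go, is how far the number depends on the ethyl group itself, which a 2-propylphenyl or an unsubstituted phenyl group on the same nitrogen would test. Also open, from the compounds shown here alone, is whether an aryl group carrying an amine or a carboxylic acid would stay at the limit or return a readable number in this assay.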